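A Third Aryl Exchange Expected to Leave Binding Unchanged

This account rests on a few compounds, and the source may have more. Where it says the series, first, only, none or still open, it means among the compounds named here.

Compound 2 `CC(C)c1ccc(-c2sc(N)c(C(=O)c3ccc(Cl)cc3)c2CC(C)(C)C)cc1` stands level with compound 1 `CC(C)(C)Cc1c(-c2ccc(F)cc2F)sc(N)c1C(=O)c1ccc(Cl)cc1`: in an assay on CHO cells for displacement of a labelled ligand from adenosine receptor A1 (Homo sapiens), read by scintillation counting, tested at 10 uM (a lower number here means less inhibition, a higher number more inhibition at the concentration tested (going by the name of the read-out)), compound 2 gives 1%, and compound 1 gives 1%. For the measured compounds named here, the one measured step, no change at the digits printed from compound 1 to compound 2 (within the scatter), exchanged one aryl group for another on the shared core without any movement. Compound 3 `CC(C)(C)Cc1c(-c2ccsc2)sc(N)c1C(=O)c1ccc(Cl)cc1` is not yet measured. It differs from compound 2 by a further exchange on the same aromatic carbon, (thiophen-3-yl in place of 4-isopropylphenyl on an aromatic carbon). Because no change at the digits printed from compound 1 to compound 2 (within the scatter) was flat, the step of a number 2 percentage points higher from compound 2 to compound 3 (within the scatter) is expected to remain within the scatter. Compound 3 is therefore estimated at 3%, with a range from -8% to 15%.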

Compound 3, a percentage reported as inhibition, at one concentration (the size of the read-out at that concentration, not a potency): 2%
Compound 3: the middle estimate sits 1 percentage points above what was measured, and the stated range covers the measured number.
By their numbers in this assay, from the lowest: compounds 1, 2 and 3 (each within the scatter of the next).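

In this assay, a five-membered aromatic ring holding a sulfur atom works no differently at this position from the six-membered carbon rings: thiophen-3-yl, with 5 heavy atoms in place of 9, gives a step within the scatter (a number 1 percentage points higher from compound 2 to compound 3 (within the scatter)), as does the exchange for 2,4-difluorophenyl (a number 1 percentage points higher from compound 1 to compound 3 (within the scatter)). Across these three aromatic groups, ring size and the presence of sulfur therefore leave the read-out level. No evidence is available on the reason for this. On these data alone, whether a non-aromatic group here, such as a carboxylic acid or an amine, would shift the number remains open. So does the effect of a longer chain in place of the neopentyl group.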